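The compounds below may be only part of what the source reports. "The series", "measured", "known", "first", "only" and "open" are said of these compounds alone.

Within the data shown here, compound 1 `COc1ccccc1-c1nnc(-c2ccc(C(=O)N/N=C/c3ccccc3O)cc2)o1` gives, in an ADME assay on THP-1 cells (Homo sapiens) for cytotoxicity (a lower number here means a stronger inhibitor, a higher number a weaker inhibitor), 207000 nM, the highest of the two numbers known. Compound 2 `COc1ccccc1-c1nnc(-c2ccc(C(=O)N/N=C/c3cccc(O)c3O)cc2)o1` gives 102000 nM, and the step of a 2.0-fold lower number from compound 1 to compound 2 (0.31 log units; beyond the scatter) comes with hydroxy in place of hydrogen on an aromatic carbon—wait.

Among the measured compounds shown here, compound 1 `COc1ccccc1-c1nnc(-c2ccc(C(=O)N/N=C/c3ccccc3O)cc2)o1` gives, in this assay, 207000 nM, the highest of the two numbers known. For the measured compounds named here, compound 2 `COc1ccccc1-c1nnc(-c2ccc(C(=O)N/N=C/c3cccc(O)c3O)cc2)o1` gives 102000 nM, so that the step of a 2.0-fold lower number from compound 1 to compound 2 (0.31 log units; beyond the scatter) stands as the only measured change on this assay. Compound 3 `COc1ccc(O)c(/C=N/NC(=O)c2ccc(-c3nnc(-c4ccccc4OC)o3)cc2)c1` differs from compound 1 by methoxy in place of hydrogen on an aromatic carbon. Going by the values given here, the one measured step bears on this only loosely, since a different group enters, and it was modest. Compound 3 is therefore expected to show at most a small step, a 1.4-fold lower number from compound 1 to compound 3 (0.14 log units; within the scatter), and its estimated value in this assay is 150000 nM, between 70000 nM and 300000 nM.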

Compound 3, half-maximal inhibitory concentration: 303000 nM
Compound 3: the middle estimate sits 2.0-fold (0.31 log units) below what was measured; the whole stated range lies below it.
By their numbers in this assay, from the lowest: compound 2; then compounds 1 and 3 (each within the scatter of the next).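

In this assay the aromatic carbon para to a hydroxy group takes methoxy in place of hydrogen with a 1.5-fold higher number from compound 1 to compound 3 (0.17 log units; within the scatter) and so without a readable change. Read as 2-hydroxy-5-methoxyphenyl in place of 2,3-dihydroxyphenyl, the change gives a 3.0-fold higher number from compound 2 to compound 3 (0.47 log units; beyond the scatter) and is the only step to compound 3 that lies beyond the scatter. Nothing available explains either step.

From the compounds shown here alone, it remains open whether an amine, a carboxylic acid or a longer chain such as ethoxy at this position would shift the number beyond the scatter. Going by these compounds, whether hydroxy at this same position would differ from methoxy is also open.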